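A few compounds are considered here, and "the series" means these few. Any claim that something is new, unique, unknown or untested is made for them only; others in the source may bear on it.

Of the compounds shown here, three sharing one core have been measured in a toxicity assay on L02 cells (Homo sapiens) for cytotoxicity, read by MTT assay, with a stated time of 72 h; on this read-out lower numbers stand for stronger inhibition and higher numbers for weaker inhibition. Compound 1 `O=C1c2c[n+]([O-])c3ccccc3c2C(=O)c2c1c1ccccc1n2Cc1cn([C@H]2C[C@H](O)[C@@H](CO)O2)nn1` gives 280 nM. Compound 2 `O=C1c2c[n+]([O-])c3ccccc3c2C(=O)c2c1c1ccccc1n2Cc1cn([C@@H]2C[C@H](O)[C@@H](CO)O2)nn1` gives 630 nM, and the pair shows a 2.3-fold higher number from compound 1 to compound 2 (0.35 log units; beyond the scatter), which rests on (the fact that compounds 1 and 2 differ only in the configuration as drawn). Compound 3 `O=C1c2c[n+]([O-])c3ccccc3c2C(=O)c2c1c1ccccc1n2Cc1cn([C@H]2O[C@H](CO)[C@@H](O)[C@H]2O)nn1` gives 950 nM, the highest of the three numbers; from compound 2 the step is a 1.5-fold higher number from compound 2 to compound 3 (0.18 log units; within the scatter), and from compound 1 it is a 3.4-fold higher number from compound 1 to compound 3 (0.53 log units; beyond the scatter).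

Compound 4 `CC1(C)OC[C@@H](Cn2cc(Cn3c4c(c5ccccc53)C(=O)c3c[n+]([O-])c5ccccc5c3C4=O)nn2)O1` is not yet measured. It differs from compound 3 in one place: (2,2-dimethyl-1,3-dioxolan-4-yl)methyl in place of 3,4-dihydroxy-5-(hydroxymethyl)oxolan-2-yl on an aromatic nitrogen. The measured steps that touch the same region of the structure are small: the change of one hydroxy on the saturated ring gave a 1.5-fold higher number from compound 2 to compound 3 (0.18 log units; within the scatter), a stereochemical inversion gave a 2.3-fold higher number from compound 1 to compound 2 (0.35 log units; beyond the scatter), and the larger rearrangement of the sugar gave a 3.4-fold higher number from compound 1 to compound 3 (0.53 log units; beyond the scatter). Replacing the whole sugar by the (2,2-dimethyl-1,3-dioxolan-4-yl)methyl group is a bigger change than any of these, so the expectation is held loosely. On the measured steps, a step of modest size toward a lower number is expected, of the order of a 1.7-fold lower number from compound 3 to compound 4 (0.24 log units; within the scatter). Compound 4 is therefore estimated to give 550 nM in this assay, with a range from 200 nM to 1500 nM.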

Compound 4, half-maximal inhibitory concentration: 2900 nM
For compound 4 the middle estimate is 5.3-fold (0.72 log units) below the measured one; measured number outside the range, above it.
By their numbers in this assay, from the lowest: compound 1; then compounds 2 and 3 (each within the scatter of the next); then compound 4.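

At this position the sugar is not interchangeable with the (2,2-dimethyl-1,3-dioxolan-4-yl)methyl group: in this assay, replacing 3,4-dihydroxy-5-(hydroxymethyl)oxolan-2-yl, with its 3 hydrogen-bond donors, by this group with 0 donors gives a 3.1-fold higher number from compound 3 to compound 4 (0.48 log units; beyond the scatter). The same kind of replacement on the 4-hydroxy-5-(hydroxymethyl)oxolan-2-yl compounds gives a 4.6-fold higher number from compound 2 to compound 4 (0.66 log units; beyond the scatter) and a 10-fold higher number from compound 1 to compound 4 (1.02 log units; beyond the scatter), so compound 4 has the highest number of the series, beyond the scatter from each of the others, and the last step is the only large one seen so far. The replacement therefore measures differently from its two closest starting points, whose own gap has a simple structural basis: the fact that compounds 1 and 2 differ only in the configuration as drawn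

As far as these compounds go, what remains open is which part of the change matters, since the hydroxy groups, the ring with 2 hetero atoms and the two methyl groups all change together in this one step. The compounds shown do not tell how an open-chain 2,3-dihydroxypropyl group or a chain ending in an amine on the same aromatic nitrogen would compare in this assay.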